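Allyl ester of a glycosylated core: an expected inactive analogue

The source may hold more compounds than are shown below. What is called first, only, known or untested is meant among the compounds shown, and "the series" means these compounds.

Measured compounds:
- Compound 1, `C/C=C1/[C@H](O[C@@H]2O[C@H](CO)[C@@H](O)[C@H](O)[C@H]2O)OC=C(C(=O)OC)[C@H]1CC(=O)OCc1ccc2c(c1)OCCO2`: in a functional assay on SK-BR-3 cells (Homo sapiens) for antiproliferative activity, read by MTT assay, with a stated time of 72 h (a higher number here means a weaker inhibitor, a lower number a stronger inhibitor), compound 1 gives > 15000 nM, which is a limit of the assay and not a number.
- Compound 2, `C#CCOC(=O)C[C@@H]1C(C(=O)OC)=CO[C@@H](O[C@@H]2O[C@H](COC(C)=O)[C@@H](OC(C)=O)[C@H](OC(C)=O)[C@H]2OC(C)=O)/C1=C/C`: in this assay compound 2 gives > 15000 nM, again only a limit.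
- Compound 3, `C/C=C1/[C@H](O[C@@H]2O[C@H](CO)[C@@H](O)[C@H](O)[C@H]2O)OC=C(C(=O)OC)[C@H]1CC(=O)OC`: in this assay compound 3 gives > 15000 nM, also a limit.

Compound 2 therefore stands at the same limit as the other two; no number places it above or below them. Among the measured compounds shown here, the only single-point comparison among the measured compounds, a step that the two limits leave unreadable from compound 1 to compound 3, cannot be read because both ends sit at the limit, so it gives no guide to how changes on that ester chain move the read-out. The shared picture is the limit of > 15000 nM in this assay, at which 3 of the 3 values shown sit.

Compound 4, `C=CCOC(=O)C[C@@H]1C(C(=O)OC)=CO[C@@H](O[C@@H]2O[C@H](COC(C)=O)[C@@H](OC(C)=O)[C@H](OC(C)=O)[C@H]2OC(C)=O)/C1=C/C`, differs from compound 2 by vinyl in place of ethynyl on a saturated chain carbon bound to an oxygen next to a carbonyl group. For the measured compounds named here, no measured step bears on this change, and nothing in the data suggests activity will appear. The step is expected to be a step that the limit leaves unreadable from compound 2 to compound 4, meaning no change beyond the scatter. Compound 4 is expected at 20000 nM, between 8000 nM and 60000 nM, most likely reported only as a limit.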

Compound 4, half-maximal inhibitory concentration: > 20000 nM
Compound 4 ended at the assay's limit; the forecaster's own chance of this, stated with the estimate: 90%; the middle value sits exactly at the limit.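

No size can be read for the change from propargyl to allyl between compound 2 and compound 4: each gives only a limit in this assay. The compounds shown leave open whether any change to the ester chain or the shared core would give a measurable antiproliferative value.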